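A few compounds are considered here, and "the series" means these few. Any claim that something is new, unique, unknown or untested is made for them only; others in the source may bear on it.

Compound 1 `Cc1c(C)c2c(c(C)c1N)CC(C)(CSc1ccc(O)cc1)O2`: > 50 mg/kg
Compound 2 `Cc1c(C)c2c(c(C)c1N)CC(C)(CSc1nccn1C)O2`: 37.1 mg/kg

In a functional assay on the whole organism with Mus musculus as the target (on this read-out higher numbers stand for an effect only at larger amounts of compound and lower numbers for an effect already at smaller amounts), compound 1 gives > 50 mg/kg, which is a limit of the assay and not a number. In this assay compound 2 gives 37.1 mg/kg, the only number shown in this series. The other shown value, that of compound 1, is a limit (the limit of > 50 mg/kg in this assay, at which 1 of the 2 values shown sits). The step of an at least 1.3-fold lower number from compound 1 to compound 2 (0.12 log units; that floor lies within the scatter) is the only measured one. Compound 3 `Cc1c(C)c2c(c(C)c1N)CC(C)(CN1CCN(C)CC1)O2` differs from compound 2 by 4-methylpiperazin-1-yl in place of (1-methyl-1H-imidazol-2-yl)sulfanyl on a saturated chain carbon bound to a saturated ring carbon. That step changes a different kind of group from the measured one, so no shown step bears on it directly, and no change beyond the scatter is expected: the estimate is a 1.2-fold lower number from compound 2 to compound 3 (0.09 log units; within the scatter). For compound 3 an estimated value of 30 mg/kg is expected, in the range 10 mg/kg to 100 mg/kg.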

Compound 3, dose for 50% inhibition: 25.3 mg/kg
Compound 3: the middle estimate sits 1.2-fold (0.07 log units) above what was measured; measured number inside the range.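

In this assay, replacing (1-methyl-1H-imidazol-2-yl)sulfanyl with 4-methylpiperazin-1-yl on a saturated chain carbon bound to a saturated ring carbon gives a 1.5-fold lower number from compound 2 to compound 3 (0.17 log units; within the scatter). This place therefore accepts a non-aromatic six-membered ring without sulfur as well as a five-membered aromatic ring carried on sulfur, with no change beyond the scatter. Neither the sulfur nor the aromatic ring is needed to keep a number of this size.

As far as these compounds go, compound 1 remains a limit of the assay and not a number: the limit of > 50 mg/kg in this assay, at which 1 of the 3 values shown sits. Whether a dimethylamino group, a carboxylic acid or a longer chain at this place would keep such a number stays open.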